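Cytotoxicity limits across a fused bicyclic amide series

The source may report more compounds than this note shows. Statements on the series, on what has been measured and on what is new or still open speak of the compounds shown alone.

Compound 1 `Cc1nc(C)c(C(=O)Nc2ccc(F)c(-c3nc4ncc(-c5cccnc5Cl)cn4n3)c2)o1` is read only at the limit of an ADME assay on HepG2 cells (Homo sapiens) for cytotoxicity, read by resazurin assay, with a stated time of 48 h (a higher number here means that more compound is needed for the effect, a lower number that less compound is needed), where it gives > 50000 nM. Compound 2 `Cc1nc(C)c(C(=O)Nc2ccc(F)c(-c3nc4ncc(-c5ccccc5Cl)cn4n3)c2)o1` is also reported as a limit in this assay, at > 50000 nM. For the measured compounds named here, the single measured step, a step that the two limits leave unreadable from compound 1 to compound 2, therefore cannot be sized. Compound 3 `O=C(Nc1ccc(F)c(-c2nc3ncc(-c4ccc(F)c(F)c4)cc3[nH]2)c1)N1CCCC1` stands no differently: in this assay compound 3 gives a limit, > 50000 nM. Where compound 3 stands is thus fixed only by the limit of > 50000 nM in this assay, at which 3 of the 3 values shown sit.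

Compound 4 `O=C(Nc1ccc(F)c(-c2nc3ncc(C(F)(F)F)cc3[nH]2)c1)N1CCCC1` differs from compound 3 by trifluoromethyl in place of 3,4-difluorophenyl on an aromatic carbon. Going by the values given here, none of the measured steps bears on this change, and the one step available, a step that the two limits leave unreadable from compound 1 to compound 2, is unreadable. Because (the limit of > 50000 nM in this assay, at which 3 of the 3 values shown sit), no step beyond the scatter is expected here, in either direction. Compound 4 is expected to give 50000 nM, within 25000 nM to 100000 nM. The step from compound 3 to compound 4 is accordingly expected to be a number no higher from compound 3 to compound 4 (the limit leaves the size open), with the result most likely returned as a limit once more.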

Compound 4, half-maximal effective concentration: > 50000 nM
Compound 4 ended at the assay's limit; the forecaster's own chance of this, stated with the estimate: 85%; the middle value sits exactly at the limit.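

Compound 3 and compound 4 both stand as limits in this assay, so the trifluoromethyl change yields no readable step: the limit of > 50000 nM in this assay, at which 4 of the 4 values shown sit. The compounds shown leave open how far any of the four lies from that limit, and whether either change alters cytotoxicity.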